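The source may report more compounds than this note shows. Statements on the series, on what has been measured and on what is new or still open speak of the compounds shown alone.

Measured in an assay on V79MZh11B1 cells for inhibition of cytochrome P450 11B1, mitochondrial (Homo sapiens), read by HPLC, with a stated time of 25 min; a higher number here means a weaker inhibitor, a lower number a stronger inhibitor:

- compound 1, `COc1ccc(COc2ccc3c(Cn4ccnc4)cc(=O)oc3c2)cc1OC`: 57 nM
- compound 2, `COc1ccc(COc2ccc3c(Cn4ccnc4)cc(=O)oc3c2)cc1`: 80 nM

Going by the values given here, compound 2 has the higher of the two numbers, but its only neighbour, compound 1, sits close: the step of a 1.4-fold higher number from compound 1 to compound 2 (0.15 log units; within the scatter) comes from hydrogen in place of methoxy on an aromatic carbon and stays within the usual scatter of repeated measurements.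

Compound 3, `Cc1cccc(COc2ccc3c(Cn4ccnc4)cc(=O)oc3c2)c1`, is the next compound to be measured in this assay. It differs from compound 2 in one place: 3-methylphenyl in place of 4-methoxyphenyl on a saturated chain carbon bound to an oxygen on an aromatic ring. Among the compounds with values here, the only measured step that bears on this change is the one from compound 1 to compound 2, where trimming a methoxy from this same aromatic ring hardly moved the number. Within the data shown here, no measured step shows what a methyl on this ring does. The step of a 1.3-fold higher number from compound 2 to compound 3 (0.10 log units; within the scatter) is therefore expected to be small, with no clear direction beyond the scatter. Compound 3 is estimated at 100 nM, with a range from 40 nM to 250 nM.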

Compound 3, half-maximal inhibitory concentration: 45 nM
Compound 3: middle estimate off by 2.2-fold (0.35 log units), on the high side, within the range that was stated.
By their numbers in this assay, from the lowest: compounds 3, 1 and 2 (each within the scatter of the next).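

In this assay, the swap from 4-methoxybenzyl to 3-methylbenzyl gives a small step (a 1.8-fold lower number from compound 2 to compound 3 (0.25 log units; within the scatter)), the first view of a methyl on this ring. Together with compound 1 and compound 2, this shows that the ring can lose its last methoxy, and with it the only hydrogen-bond acceptor in the group, with no change beyond the scatter. Why the number stays in this range cannot be said, as no supporting measurement bears on this result.

On these data alone, the group and its place on the ring change together in this step, so the contribution of each remains unknown. As far as these compounds go, it also remains open whether a more different group on this ring, such as an amine or a carboxylic acid, would move the number beyond the scatter.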